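This account rests on a few compounds, and the source may have more. Where it says the series, first, only, none or still open, it means among the compounds named here.

Measured compounds:
compound 1 `CC[C@H](CCn1cncn1)c1ccccc1` 99.8 ug/mL
compound 2 `CCC[C@H](CCn1cncn1)c1ccccc1` 63.1 ug/mL
compound 3 `CCC[C@@H](CCn1cncn1)c1ccc(Cl)cc1` 40.8 ug/mL

In an ADME assay on RD cells (Homo sapiens) for cytotoxicity, read by MTT assay, with a stated time of 3 days (a lower number here means that less compound is tolerated, a higher number that more compound is tolerated), compound 2 gives 63.1 ug/mL, the second highest of the three numbers shown. Its nearest neighbour is compound 3, which gives 40.8 ug/mL, and its furthest is compound 1, which gives 99.8 ug/mL; both gaps from compound 2 are within the scatter, so the three compounds cannot be separated on the numbers shown.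

Compound 4 `CCC[C@H](CCn1cncn1)c1ccc(C)cc1` has not yet been measured in this assay. It differs from compound 2 as follows: methyl in place of hydrogen on an aromatic carbon.

Going by the values given here, the only step with measured ends is a 1.6-fold lower number from compound 1 to compound 2 (0.20 log units; within the scatter). That step changes the chain, not the ring, so it does not speak directly to the change leading to compound 4; it shows only that a single added carbon on this scaffold left this assay within the scatter. Compound 3 and compound 2 carry different ring substituents, and their two values also lie within the scatter of each other. Among the compounds with values here, no measured step therefore suggests a shift beyond the scatter for compound 4, and no direction can be read from the data.

For compound 4 the expected step is a 1.3-fold lower number from compound 2 to compound 4 (0.10 log units; within the scatter). Compound 4 is estimated at 50 ug/mL, with a range from 25 ug/mL to 100 ug/mL.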

Compound 4, half-maximal cytotoxic concentration: 47.2 ug/mL
Beside the measured number, compound 4's estimate is 1.1-fold (0.03 log units) above it; the range from low to high includes it.
By their numbers in this assay, from the lowest: compounds 3, 4, 2 and 1 (each within the scatter of the next, the first and the last beyond it).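

In this assay, going by these compounds alone, methyl in place of hydrogen on an aromatic carbon, para to a large group, gives a 1.3-fold lower number from compound 2 to compound 4 (0.13 log units; within the scatter) and is the first step with measured ends that touches the ring and not the chain. This ring position therefore takes a single added carbon with no shift beyond the scatter, and the same holds for the earlier change on the chain, a 1.6-fold lower number from compound 1 to compound 2 (0.20 log units; within the scatter) in the same assay. No measurement bearing on the reason for this result is available, so the step stands as a bare number.

Still open, going by these compounds, is whether a group other than methyl at this ring position, such as methoxy, an amine or a carboxylic acid, would move the number beyond the scatter, since methyl alone has been compared with hydrogen here. Also open, on these data alone, is whether a longer chain on the saturated carbon, taken one place at a time on the core of compound 2, would stay within the scatter as the single added carbon did.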